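Swapping the chlorines for methoxy groups on a benzylamine

A few compounds are considered here, and "the series" means these few. Any claim that something is new, unique, unknown or untested is made for them only; others in the source may bear on it.

Compound 1, `Nc1cc(N)c2nc(-c3ccccc3)c(NCc3ccc(Cl)c(Cl)c3)nc2c1`: 5890 nM
Compound 2, `CCOC(=O)[C@H](CCC(=O)O)NC(=O)c1ccc(Sc2nc3cc(N)cc(N)c3nc2-c2ccccc2)cc1`: < 100000 nM

In a functional assay on IGROV-1 cells (Homo sapiens) for inhibition, read by sulforhodamine B assay, with a stated time of 48 h (on this read-out higher numbers stand for weaker inhibition of growth and lower numbers for stronger inhibition of growth), compound 1 gives 5890 nM. Among the measured compounds shown here, that is the only number measured so far in this assay. For compound 2 the assay reports only a limit, < 100000 nM, which is not a number but the edge of what the assay could read; as the limit of < 100000 nM in this assay, at which 1 of the 2 values shown sits, notes, one of the two values shown sits at this limit. For the measured compounds named here, no pair of measured compounds differs in a single place, so no measured step is available.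

The step now followed leads from compound 1 to compound 3, `COc1ccc(CNc2nc3cc(N)cc(N)c3nc2-c2ccccc2)cc1OC`. The change is 3,4-dimethoxyphenyl in place of 3,4-dichlorophenyl on a saturated chain carbon bound to a nitrogen on an aromatic ring. Both groups are six-membered aromatic rings of carbon only, so the shape of the side arm is kept, while the two chlorines give way to two methoxy groups that add two hydrogen-bond acceptors.

Going by the values given here, with no measured step to lean on, the step of a 1.5-fold higher number from compound 1 to compound 3 (0.18 log units; within the scatter) is expected to be small, toward weaker inhibition, and possibly no larger than the scatter. Compound 3 is estimated at 9000 nM, with a range from 2500 nM to 30000 nM.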

Compound 3, concentration for total growth inhibition: 40700 nM
Compound 3: middle estimate off by 4.5-fold (0.66 log units), on the low side; the measured number lies above the stated range.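

Among the compounds shown here, the swap gives a 6.9-fold higher number from compound 1 to compound 3 (0.84 log units; beyond the scatter) in this assay, the first measured step at this position, and the higher number means weaker inhibition of growth. Keeping a six-membered aromatic ring of carbon only on the saturated chain carbon is therefore not enough to hold the activity: in this pair, the groups carried by that ring matter, and 3,4-dichlorophenyl gives stronger inhibition of growth than 3,4-dimethoxyphenyl. Nothing measured here explains the step, so it cannot be assigned to the added hydrogen-bond acceptors, the larger group or anything else.

With a single pair, the compounds shown leave open whether the loss of the chlorines or the arrival of the methoxy groups drives the step, a question that a plain phenyl, carrying neither, could help to separate. They also leave open how far this position tolerates a different kind of group, such as an amine or a carboxylic acid in place of the aromatic ring, and whether any such group would give stronger inhibition of growth than 3,4-dichlorophenyl.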